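Thiophene in place of trimethoxyphenyl on a dienone scaffold

The source may report more compounds than this note shows. Statements on the series, on what has been measured and on what is new or still open speak of the compounds shown alone.

Among three dienone-triazole-coumarin conjugates tested in a functional assay on THP-1 cells (Homo sapiens) for inhibition, read by sulforhodamine B assay, with a stated time of 48 h, tested at 50 uM (a lower number here means less inhibition of growth, a higher number more inhibition of growth at the concentration tested), compound 2 `COc1cc(/C=C/C(=O)/C=C/c2cc(OC)c(OC)c(OC)c2)ccc1OCc1cn(CCCOc2cc(=O)oc3ccccc23)nn1` stands highest with 79%. Compound 3 `COc1ccc(/C=C/C(=O)/C=C/c2ccc(OCc3cn(CCOc4cc(=O)oc5ccccc45)nn3)c(OC)c2)cc1` gives 78%, which lies within the scatter of compound 2, so the two cannot be ranked. Compound 1 `COc1ccc(/C=C/C(=O)/C=C/c2ccc(OCc3cn(CCCCCOc4cc(=O)oc5ccccc45)nn3)c(OC)c2)cc1` gives 39%, well beyond the scatter below compound 2. Within the data shown here, no single-point step between measured compounds is available, so the size of a change in this assay must be judged from the structural change alone. Compound 4 `COc1cc(/C=C/C(=O)/C=C/c2cccs2)ccc1OCc1cn(CCCOc2cc(=O)oc3ccccc23)nn1` differs from compound 2 as follows: thiophen-2-yl in place of 3,4,5-trimethoxyphenyl on a double-bonded chain carbon bound to a double-bonded chain carbon. This is a sizeable exchange, and a moderate drop in this assay is expected, with the step from a number 19 percentage points lower from compound 2 to compound 4 (beyond the scatter) estimated as a loss beyond the scatter. Compound 4 is therefore expected to give 60% in this assay, within a range of 35% to 85%.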

Compound 4, percent growth inhibition at one concentration: 54%
Compound 4: middle estimate off by 6 percentage points, on the high side; the measured number falls inside the stated range.
By their numbers in this assay, from the lowest: compound 1; then compound 4; then compounds 3 and 2 (each within the scatter of the next).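

Putting thiophen-2-yl in place of 3,4,5-trimethoxyphenyl gives a number 25 percentage points lower from compound 2 to compound 4 (beyond the scatter) in this assay, so the group at this place bears on growth inhibition. With fewer heavy atoms at this place, compound 4 still gives 54%, so the 3,4,5-trimethoxyphenyl group is not required for inhibition at the concentration tested. Nothing available explains the loss.

Going by these compounds, whether a furan-2-yl or pyridin-2-yl group would behave like thiophen-2-yl remains open. So does whether the sulfur atom or the smaller ring accounts for the difference.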